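Sulfonyl aryl change on the shared core

This account rests on a few compounds, and the source may have more. Where it says the series, first, only, none or still open, it means among the compounds named here.

Of the compounds shown here, three sharing one core have been measured in an assay on isolated protein for displacement of a labelled ligand from metabotropic glutamate receptor 5 (Homo sapiens), with a stated time of 60 min, tested at 1 uM; on this read-out lower numbers stand for less inhibition and higher numbers for more inhibition at the one concentration tested (going by the name of the read-out). Compound 1 `CC1CCN(c2c(S(=O)(=O)c3cccc(Cl)c3)cnc3cc(Cl)ccc23)CC1` gives 92%, the highest of the three numbers. Compound 2 `Cc1ccc2ncc(S(=O)(=O)c3cc(Cl)cc(Cl)c3)c(N3CCC(C)CC3)c2c1` gives 75% in this assay, a number lower than that of compound 1 by more than the usual scatter, and compound 3 `COc1ccc2ncc(S(=O)(=O)c3cc(F)cc(F)c3)c(N3CCC(C)CC3)c2c1` gives 30%, the furthest from compound 1, also beyond the scatter. Compound 4 `COc1ccc(S(=O)(=O)c2cnc3cc(Cl)ccc3c2N2CCC(C)CC2)cc1` has not been measured. It differs from compound 1 in one place: 4-methoxyphenyl in place of 3-chlorophenyl on a sulfonyl sulfur. Among the compounds with values here, no measured pair isolates this change, so the expectation rests on the spread of the three numbers alone. The expected step is a number 37 percentage points lower from compound 1 to compound 4 (beyond the scatter), a decrease beyond the scatter. Compound 4 is expected to give about 55% in this assay, within 25% to 85%.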

Compound 4, a percentage reported as inhibition, at one concentration (the size of the read-out at that concentration, not a potency): 79%
The estimate for compound 4 lay 24 percentage points below the measured number; the range from low to high includes it.
By their numbers in this assay, from the lowest: compound 3; then compounds 2 and 4 (each within the scatter of the next); then compound 1.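

In this assay, within the data shown here, 4-methoxyphenyl in place of 3-chlorophenyl on a sulfonyl sulfur gives a number 13 percentage points lower from compound 1 to compound 4 (beyond the scatter), the first step that isolates a change at this position. With the rest of the core of compound 1 held fixed, compound 4 still reaches 79%, so this position accepts an aryl group without chlorine at a modest cost. Nothing available explains this step.

As far as these compounds go, whether the step follows from losing the chlorine or from gaining the methoxy remains open. So does the effect of a phenyl carrying an amine or a carboxylic acid on the sulfonyl sulfur.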